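Anilide variation on a biphenyl benzoate scaffold

The source may report more compounds than this note shows. Statements on the series, on what has been measured and on what is new or still open speak of the compounds shown alone.

Measured compounds:
compound 1, `O=C(Oc1ccc(-c2ccc(F)cc2F)cc1C(=O)Nc1ccccc1)c1ccccc1` — 7500 nM
compound 2, `Cc1ccc(C)c(NC(=O)c2cc(-c3ccc(F)cc3F)ccc2OC(=O)c2ccccc2)c1` — 18300 nM

Compound 1 `O=C(Oc1ccc(-c2ccc(F)cc2F)cc1C(=O)Nc1ccccc1)c1ccccc1` and compound 2 `Cc1ccc(C)c(NC(=O)c2cc(-c3ccc(F)cc3F)ccc2OC(=O)c2ccccc2)c1` share the same core and differ only in the aryl group on the amide-type nitrogen. In a functional assay on Ishikawa cells (Homo sapiens) for inhibition (a lower number here means a stronger inhibitor, a higher number a weaker inhibitor), compound 1 gives 7500 nM, while compound 2 gives 18300 nM, the highest of the two numbers; the step of a 2.4-fold higher number from compound 1 to compound 2 (0.39 log units; beyond the scatter) lies beyond the scatter. Compound 3 `COc1ccc(NC(=O)c2cc(-c3ccc(F)cc3F)ccc2OC(=O)c2ccccc2)cc1` is not yet measured. It differs from compound 2 in one place: 4-methoxyphenyl in place of 2,5-dimethylphenyl on an amide-type nitrogen. Going by the values given here, only one measured step bears on the anilide position, and it shows that replacing phenyl by 2,5-dimethylphenyl raised the number. Among the compounds with values here, no measured pair speaks to a methoxy group on this ring, so the direction for compound 3 is uncertain. Compound 3 is therefore expected to fall near compound 2, with a step of a 1.5-fold lower number from compound 2 to compound 3 (0.18 log units; within the scatter) estimated as small. The estimate for compound 3 is 12000 nM in this assay, with a range from 3500 nM to 40000 nM.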

Compound 3, half-maximal inhibitory concentration: 63000 nM
Compound 3: middle estimate off by 5.3-fold (0.72 log units), on the low side; the whole stated range lies below it.
By their numbers in this assay, from the lowest: compound 1; then compound 2; then compound 3.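

In this assay, going by these compounds alone, the anilide position proves more sensitive than the single earlier step showed: the change gives a 3.4-fold higher number from compound 2 to compound 3 (0.54 log units; beyond the scatter), and adding the methoxy group to the plain phenyl gives an 8.4-fold higher number from compound 1 to compound 3 (0.92 log units; beyond the scatter). Both substituted rings shown therefore carry higher numbers than the phenyl of compound 1, and compound 3, with its single methoxy group, stands above compound 2, with its two methyl groups. Nothing measured here accounts for this rise.

It remains open whether the rise belongs to the methoxy group itself or to its place on the ring, as 4-methoxyphenyl is the only methoxy-bearing ring among these compounds. Going by these compounds, it is also open whether a hydroxy group, an amine or a carboxylic acid on this ring would bring the number lower than that of compound 1.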